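Chloro substitution on the pendant phenyl of compound 3

The source may report more compounds than this note shows. Statements on the series, on what has been measured and on what is new or still open speak of the compounds shown alone.

Compound 3 `COc1cc(-n2cnc3ccc(-c4ccccc4)cc32)cc(OC)c1OC` stands highest of the two numbers measured; in a functional assay on A549 cells (Homo sapiens) for antiproliferative activity, read by MTT assay, with a stated time of 72 h (on this read-out higher numbers stand for weaker inhibition and lower numbers for stronger inhibition), compound 3 gives 3060 nM. Compound 1 `COc1cc(-n2cnc3ccc(-c4cccc(N)c4)cc32)cc(OC)c1OC` sits nearest, and in this assay compound 1 gives 640 nM, the step of a 4.8-fold higher number from compound 1 to compound 3 (0.68 log units; beyond the scatter) being hydrogen in place of amino on an aromatic carbon. Compound 2 `COc1ccc(-c2ccc3ncn(-c4cc(OC)c(OC)c(OC)c4)c3c2)cc1` reaches only a limit in this assay, > 10000 nM. The step of an at least 3.2-fold lower number from compound 2 to compound 3 (0.51 log units; beyond the scatter) shows that hydrogen in place of methoxy on an aromatic carbon runs the other way, partly against the limit (the limit of > 10000 nM in this assay, at which 1 of the 3 values shown sits).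

Compound 4 `COc1cc(-n2cnc3ccc(-c4cccc(Cl)c4)cc32)cc(OC)c1OC` differs from compound 3 by chloro in place of hydrogen on an aromatic carbon. Going by the values given here, no measured step exchanges chloro; the two steps that bear on it, a substituent on the same ring, point in opposite directions and are both of modest size. A modest step is therefore expected, with some lean toward a lower number in this assay by analogy with compound 1 and a 4.8-fold higher number from compound 1 to compound 3 (0.68 log units; beyond the scatter), so compound 4 is estimated at 2000 nM, between 600 nM and 6500 nM, which means an expected step of a 1.5-fold lower number from compound 3 to compound 4 (0.18 log units; within the scatter).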

Compound 4, half-maximal inhibitory concentration: 7050 nM
Estimate against measurement, compound 4: 3.5-fold (0.55 log units) below; the whole stated range lies below it.
By their numbers in this assay, from the lowest: compound 1; then compound 3; then compound 4. At a limit, above all of these: compound 2.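

In this assay, the place that carries amino in compound 1 does not favour every substituent: chloro in place of hydrogen on an aromatic carbon gives a 2.3-fold higher number from compound 3 to compound 4 (0.36 log units; beyond the scatter), so chloro moves the number opposite to amino. The direct exchange on this carbon is much wider, an 11-fold higher number from compound 1 to compound 4 (1.04 log units; beyond the scatter), which places amino, hydrogen and chloro in a clear order at this one position, with each step beyond the scatter. 3-Chlorophenyl in place of 4-methoxyphenyl on an aromatic carbon gives an at least 1.4-fold lower number from compound 2 to compound 4 (0.15 log units; that floor lies within the scatter), and this comparison sets no order, as one of its two ends stands only at a limit: the limit of > 10000 nM in this assay, at which 1 of the 4 values shown sits.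

Three substituents on one carbon cannot show whether the lower number of compound 1 belongs to the amine itself or to any group of that size. A hydroxyl, a methylamino or an acetamide on the same carbon would bear on this, and a fluoro or a methyl would show whether the rise seen with chloro is shared.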